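Thiazole to furan exchange on the anilide aromatic ring

A few compounds are considered here, and "the series" means these few. Any claim that something is new, unique, unknown or untested is made for them only; others in the source may bear on it.

Compound 1 `O=C(Nc1ccc(-c2cscn2)cc1)C1CCCN(Cc2ccc(F)c(F)c2)C1` gives 1240 nM in a functional assay on A-375 cells (Homo sapiens) for activation, with a stated time of 3 days; on this read-out higher numbers stand for an effect only at larger amounts of compound and lower numbers for an effect already at smaller amounts. Compound 2 `O=C(Nc1ccc(-c2cscn2)cc1)C1CCCN(Cc2cc(F)cc(F)c2)C1` gives 1500 nM, and compound 3 `O=C(Nc1ccc(-c2cscn2)cc1)C1CCCN(Cc2cccc(F)c2F)C1` gives 10000 nM. Compound 1 thus sits at the low end of the three numbers, with compound 2 within the scatter of it (a 1.2-fold higher number from compound 1 to compound 2 (0.08 log units; within the scatter)) and compound 3 beyond it (an 8.1-fold higher number from compound 1 to compound 3 (0.91 log units; beyond the scatter)); between compound 2 and compound 3 there is a 6.7-fold higher number from compound 2 to compound 3 (0.82 log units; beyond the scatter). Compound 4 `O=C(Nc1ccc(-c2ccoc2)cc1)C1CCCN(Cc2ccc(F)c(F)c2)C1` differs from compound 1 by furan-3-yl in place of 1,3-thiazol-4-yl on an aromatic carbon. Among the compounds with values here, every measured step concerns the fluorine pattern on the saturated chain carbon bound to an amine nitrogen in a ring; none touches the five-membered aromatic ring on the aromatic carbon, so no measured step bears on this change. Without precedent, compound 4 is expected near compound 1, a 1.2-fold higher number from compound 1 to compound 4 (0.08 log units; within the scatter), with a wide range. The estimate for compound 4 is 1500 nM, between 400 nM and 6000 nM.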

Compound 4, half-maximal effective concentration: 3000 nM
For compound 4 the middle estimate is 2.0-fold (0.30 log units) below the measured one; low and high end bracket the measured number.
By their numbers in this assay, from the lowest: compounds 1, 2 and 4 (each within the scatter of the next, the first and the last beyond it); then compound 3.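

The first change shown at the aromatic carbon para to a large group, furan-3-yl in place of 1,3-thiazol-4-yl, gives in this assay a 2.4-fold higher number from compound 1 to compound 4 (0.38 log units; beyond the scatter). This position therefore responds to the ring exchange, modestly, and the furan-3-yl compound keeps a measurable number. No data shown bear on the origin of this step.

The compounds shown leave open how a thiophene or pyridine ring would fare at this place. Also open, on these data alone, is whether furan-3-yl preserves the order seen across the difluorophenyl groups of compound 1, compound 2 and compound 3.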